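The compounds below may be only part of what the source reports. "The series", "measured", "known", "first", "only" and "open" are said of these compounds alone.

Compound 1, whose structure is `C=C[C@@](C)(/C=C/c1ccc(OCc2ccccc2)cc1)CCC=C(C)C`, is one of three compounds tested in a functional assay on SEM cells (Homo sapiens) for cytotoxicity, with a stated time of 72 h; on this read-out lower numbers stand for an effect already at smaller amounts and higher numbers for an effect only at larger amounts of compound. In this assay compound 1 gives only a limit, > 36600 nM, and no number. The same holds for its two companions. Compound 2, built as `C=C[C@@](C)(/C=C/c1ccc(O)cc1)CCC1OC1(C)C`, reaches only the limit > 36600 nM in this assay. Compound 3, built as `C=C[C@@](C)(/C=C/c1ccc(-c2c(F)c(F)c(F)c(F)c2F)cc1)CCC=C(C)C`, likewise stops at the limit > 36600 nM in this assay. Compound 1 therefore stands nowhere above or below the others: every value recorded is the same limit, and the limit of > 36600 nM in this assay, at which 3 of the 3 values shown sit, summarises the whole picture. Within the data shown here, no step between two measured compounds can be drawn from such data.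

Compound 4, whose structure is `C=C[C@@](C)(/C=C/c1ccc(-c2cccc(Br)c2)cc1)CCC=C(C)C`, differs from compound 1 in one place: 3-bromophenyl in place of benzyloxy on an aromatic carbon. With all three measured compounds sitting at the limit, and compound 3 already carrying a fluorinated aryl ring without effect, no step beyond the scatter is expected in this assay. Compound 4 is estimated to follow the same course, with an expected step that the limit leaves unreadable from compound 1 to compound 4 from compound 1 to compound 4. The estimate for compound 4 is therefore 40000 nM, within a range from 15000 nM to 110000 nM, most likely reported again as a limit rather than a number.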

Compound 4, half-maximal effective concentration: > 36600 nM
Compound 4: no number, only a limit; the forecaster's own chance of this, stated with the estimate: 70%; the middle value does not contradict the limit.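

In this assay compound 4 gives > 36600 nM as a limit and not a number. Among these compounds, compound 1 also gives only a limit, so no step between compound 1 and compound 4 can be read. The compounds shown leave open whether any change to the shared core would give a measurable value, as one result runs throughout: the limit of > 36600 nM in this assay, at which 4 of the 4 values shown sit.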